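The compounds below may be only part of what the source reports. "The series", "measured", "known", "first", "only" and "open" are said of these compounds alone.

Measured in a functional assay on CLL cells (Homo sapiens) for cytotoxicity, read by MTT assay, with a stated time of 48 h; a higher number here means that more compound is needed for the effect, a lower number that less compound is needed:
- compound 1 `C=C(CC)C(=O)c1ccc(OCC(=O)NCCCN2CCCC2=O)c(Cl)c1Cl`: 13800 nM
- compound 2 `C=C(CC)C(=O)c1ccc(OCC(=O)Nc2ccc(O)c([N+](=O)[O-])c2)c(Cl)c1Cl`: 7400 nM
- compound 3 `C=C(CC)C(=O)c1ccc(OCC(=O)Nc2ccc(C(=O)O)cc2)c(Cl)c1Cl`: 5000 nM

Within the data shown here, compound 3 lies within the usual scatter of compound 2, and the one measured step that reaches it is a 2.8-fold lower number from compound 1 to compound 3 (0.44 log units; beyond the scatter). That modest step replaced a chain with an aromatic group. Compound 4 `C=C(CC)C(=O)c1ccc(OCC(=O)Nc2ccc(O)c(Cl)c2)c(Cl)c1Cl` has 3-chloro-4-hydroxyphenyl in place of 4-carboxyphenyl on an amide-type nitrogen. This swap keeps a phenyl ring on that nitrogen, as compound 2 at 7400 nM also does, with a hydroxy group there too. No large change is therefore expected. The step expected in this assay is a 1.2-fold higher number from compound 3 to compound 4 (0.08 log units; within the scatter), which would stay within the scatter. Compound 4 is estimated at 6000 nM, with an expected range of 2500 nM to 14000 nM.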

Compound 4, half-maximal effective concentration: 5500 nM
Compound 4: middle estimate off by 1.1-fold (0.04 log units), on the high side; low and high end bracket the measured number.
By their numbers in this assay, from the lowest: compounds 3, 4, 2 and 1 (each within the scatter of the next, the first and the last beyond it).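

In this assay, two changes on the aromatic group at this amide-type nitrogen leave the number within the scatter: replacing 4-carboxyphenyl gives a 1.1-fold higher number from compound 3 to compound 4 (0.04 log units; within the scatter), and chloro in place of nitro gives a 1.3-fold lower number from compound 2 to compound 4 (0.13 log units; within the scatter). A second aromatic group also stands apart from the 3-(2-oxopyrrolidin-1-yl)propyl chain, with a 2.5-fold lower number from compound 1 to compound 4 (0.40 log units; beyond the scatter). Nothing available explains these numbers.

On these data alone, it remains open whether a plain phenyl group with no substituents would give a similar number. As far as these compounds go, an amine on the ring or a simple unbranched alkyl chain at this nitrogen also remains untested here.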